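Bromo for chloro on the shared core: compound 4

This account rests on a few compounds, and the source may have more. Where it says the series, first, only, none or still open, it means among the compounds named here.

In a physicochemical assay for solubility, read by HPLC, at pH 7.4 (a lower number here means a less soluble compound, a higher number a more soluble compound), compound 1 `COc1ccc2c(OC)c(Cc3ccccc3)c(C)nc2c1` gives 2000 nM. Compound 2 `CCc1c(C)[nH]c2cc(OC)c(F)cc2c1=O` gives < 2000 nM, which is a limit of the assay and not a number. Compound 3 `CCc1c(C)[nH]c2cc(OC)c(Cl)cc2c1=O` gives 10000 nM, the higher of the two actual numbers, and its gap to compound 1 lies beyond the scatter.

Compound 4 `CCc1c(C)[nH]c2cc(OC)c(Br)cc2c1=O` is still to be measured in this assay. The change is bromo in place of chloro on an aromatic carbon, ortho to a methoxy group.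

Going by the values given here, one measured step bears on it: an at least 5.0-fold higher number from compound 2 to compound 3 (0.69 log units; beyond the scatter), with chloro in place of fluoro on an aromatic carbon. That step is beyond the scatter, but a single halogen exchange sets no trend, and neither its size nor its direction can simply be carried over to the next exchange. The expectation therefore starts from compound 3 at 10000 nM, with no step beyond the scatter and no firm direction. The estimated step is a 1.3-fold lower number from compound 3 to compound 4 (0.10 log units; within the scatter), which stays within the scatter. For compound 4 the expected value is 8000 nM, with an estimated range of 2500 nM to 20000 nM.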

Compound 4, solubility: 2000 nM
Beside the measured number, compound 4's estimate is 4.0-fold (0.60 log units) above it, and the stated range ends above it.
By their numbers in this assay, from the lowest: compounds 1 and 4 (each within the scatter of the next); then compound 3.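

The aromatic carbon ortho to a methoxy group does not respond to halogen exchange in one direction in this assay: bromo in place of chloro gives a 5.0-fold lower number from compound 3 to compound 4 (0.70 log units; beyond the scatter), a step beyond the scatter. Set against an at least 5.0-fold higher number from compound 2 to compound 3 (0.69 log units; beyond the scatter), this reversal shows that the rise seen on going from fluoro to chloro does not carry on to bromo, leaving compound 3 with the highest number of the three halogen compounds on the shared core. Compound 2 carries a limit of the assay and not a number: the limit of < 2000 nM in this assay, at which 1 of the 4 values shown sits. Bromo in place of fluoro gives a number no lower from compound 2 to compound 4 (the limit leaves the size open), and the size of that step cannot be read.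

From the compounds shown here alone, whether a nitrile, an amine or a carboxylic acid on this aromatic carbon would give a number above that of compound 3 remains open. It is also open whether chloro would still stand above bromo if the ethyl group on the shared core gave way to a longer chain, since both halogens are shown with that one ethyl group only.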